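A Sulfonamide Replaces Hydrogen on the Biphenyl Arm

This account rests on a few compounds, and the source may have more. Where it says the series, first, only, none or still open, it means among the compounds named here.

Compound 2 `O=C(O)CC/C=C\CO[C@H]1[C@@H](OCc2ccc(-c3ccccc3)cc2)CC[C@@H]1N1CCCCCC1` gives 39.8 nM in a functional assay for antagonist activity at thromboxane A2 receptor (Rattus norvegicus) (a higher number here means weaker binding, a lower number tighter binding), the highest of the two numbers recorded; its nearest neighbour is compound 1 `O=C(O)CC/C=C\CO[C@H]1[C@@H](OCc2ccc(-c3ccccc3CO)cc2)CC[C@@H]1N1CCCCCC1`, which in this assay gives 12.6 nM. Going by the values given here, the one step measured so far, a 3.2-fold higher number from compound 1 to compound 2 (0.50 log units; beyond the scatter), is a hydrogen in place of hydroxymethyl on an aromatic carbon. Compound 3 `CS(=O)(=O)Nc1ccccc1-c1ccc(CO[C@H]2CC[C@H](N3CCCCCC3)[C@H]2OC/C=C\CCC(=O)O)cc1` is not yet measured; it differs from compound 2 by methanesulfonamido in place of hydrogen on an aromatic carbon. Among the compounds with values here, the single measured step bears on this change, since it too concerns a substituent on an aromatic carbon of the shared core, and it was modest but beyond the scatter. A step of comparable size in the opposite direction is therefore expected for compound 3, lowering the number in this assay: a 3.3-fold lower number from compound 2 to compound 3 (0.52 log units; beyond the scatter). Compound 3 is estimated at 12 nM, with a range from 4 nM to 40 nM.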

Compound 3, dissociation constant: 63.1 nM
For compound 3 the middle estimate is 5.3-fold (0.72 log units) below the measured one; measured number outside the range, above it.
By their numbers in this assay, from the lowest: compound 1; then compounds 2 and 3 (each within the scatter of the next).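

At this aromatic carbon, ortho to a large group, the earlier pair had shown only that hydroxymethyl and hydrogen can be told apart in this assay and that a substituent here can matter. Methanesulfonamido cannot be told apart from hydrogen, with a 1.6-fold higher number from compound 2 to compound 3 (0.20 log units; within the scatter) as its step, so a larger group at this place does not by itself change the reading. Against hydroxymethyl it does separate, with a 5.0-fold higher number from compound 1 to compound 3 (0.70 log units; beyond the scatter) as its step, which leaves hydroxymethyl alone among these three groups, though nothing available accounts for that difference.

From the compounds shown here alone, how a carboxylic acid, an amine or a methoxy group on this carbon would read in this assay stays open. So does whether hydroxymethyl is unusual here or simply the first of several groups that stand apart from hydrogen.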